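A few compounds are considered here, and "the series" means these few. Any claim that something is new, unique, unknown or untested is made for them only; others in the source may bear on it.

Compound 1 `Cc1ccc(-c2cnn3c(NCc4ccccn4)cc(C)nc23)cc1`: in a physicochemical assay for solubility, read by HPLC, using the shake flask method, measured as kinetic solubility, with a stated time of 2 h, at pH 7.4 (a higher number here means a more soluble compound, a lower number a less soluble compound), compound 1 gives only a limit, < 5000 nM.
Compound 2 `Cc1cc(NCc2ncc[nH]2)n2nc(C)c(-c3ccccc3)c2n1`: in this assay compound 2 also gives only a limit, < 5000 nM.
Compound 3 `Cc1cc(NCc2ccco2)n2nc(C)c(-c3ccccc3)c2n1`: in this assay compound 3 likewise gives only a limit, < 5000 nM.

Compound 1 therefore stands at the limit of < 5000 nM in this assay, at which 3 of the 3 values shown sit, together with the other two measured compounds, and no number separates any of them. Among the compounds with values here, the only measured step between two of them, a step that the two limits leave unreadable from compound 2 to compound 3, cannot be read because both of its ends are limits. Compound 4 `Cc1cc(NCc2ccccn2)n2ncc(-c3ccc(N(C)C)cc3)c2n1` carries dimethylamino in place of methyl on an aromatic carbon. Within the data shown here, no measured step touches that position, and the one measured step has no readable size, so the data give no ground for expecting a movement in this assay beyond the scatter in either direction. Compound 4 is accordingly expected to show a step that the limit leaves unreadable from compound 1 to compound 4, and most probably to come back as a limit once more. For compound 4 the estimate is 4000 nM, within a range from 1000 nM to 15000 nM.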

Compound 4, solubility: < 5000 nM
Compound 4 gave a limit, no number (the forecaster's own chance of this, stated with the estimate: 70%); the middle value is on the limit's open side.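

In this assay compound 4 gives only a limit, < 5000 nM. No new step can be read, as compound 1 and compound 4 both stand at limits. The compounds shown leave open whether dimethylamino in place of methyl shifts the read-out at all, and how they rank: the limit of < 5000 nM in this assay, at which 4 of the 4 values shown sit.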